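Sulfone to sulfide, 4-chlorophenyl to 2-bromophenyl: growth inhibition

The compounds below may be only part of what the source reports. "The series", "measured", "known", "first", "only" and "open" are said of these compounds alone.

Compound 1 `Cc1ccc(CS(=O)(=O)/C(=C/c2ccc(Cl)cc2)C(=O)c2ccc(Cl)cc2)cc1`: 25000 nM
Compound 2 `Cc1ccc(CS(=O)(=O)/C(=C/c2ccccc2Br)C(=O)c2ccc(Cl)cc2)cc1`: 25000 nM
Compound 3 `Cc1ccc(CS/C(=C/c2ccc(Cl)cc2)C(=O)c2ccc(Cl)cc2)cc1`: 10000 nM

Of the compounds shown here, three have been measured in a functional assay on DU-145 cells (Homo sapiens) for inhibition, read by trypan blue exclusion, with a stated time of 96 h; a higher number here means a weaker inhibitor of growth, a lower number a stronger inhibitor of growth. Compound 1 gives 25000 nM in this assay, and compound 2, which carries 2-bromophenyl in place of 4-chlorophenyl on a double-bonded chain carbon bound to a double-bonded chain carbon, gives 25000 nM; the step of no change at the digits printed from compound 1 to compound 2 (within the scatter) shows the change leaving the number where it was. Compound 3 gives 10000 nM in this assay, the lowest of the three numbers, and the difference between its core and the core of compound 1 is not broken down here.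

Compound 4 `Cc1ccc(CS/C(=C/c2ccccc2Br)C(=O)c2ccc(Cl)cc2)cc1` has not yet been measured. It differs from compound 3 by 2-bromophenyl in place of 4-chlorophenyl on a double-bonded chain carbon bound to a double-bonded chain carbon, the same change as from compound 1 to compound 2, at the same place. Because no change at the digits printed from compound 1 to compound 2 (within the scatter) was flat within the scatter, compound 4 is expected to stay close to compound 3, with an estimated step of no change at the digits printed from compound 3 to compound 4 (within the scatter) in this assay. Compound 4 is therefore estimated at 10000 nM, with a range of 5000 nM to 25000 nM, resting on a single earlier instance of this change.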

Compound 4, concentration for 50% growth inhibition: 10000 nM
For compound 4 middle estimate and measured number coincide at the digits printed; low and high end bracket the measured number.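

In this assay, 2-bromophenyl in place of 4-chlorophenyl on the second core gives no change at the digits printed from compound 3 to compound 4 (within the scatter), so the change behaves on this core as it did on the first: the same change on two cores in this assay, no change at the digits printed (within the scatter) from compound 1 to compound 2 and no change at the digits printed (within the scatter) from compound 3 to compound 4, 1.0-fold (0.00 log units) apart, within the scatter of two such steps. The printed numbers also keep their distance across the two cores, with compound 2 at 25000 nM and compound 4 at 10000 nM, so the swap leaves the difference between the cores as it stood with 4-chlorophenyl. This shows that one flat change carried over once, in a single cell assay, but it does not show that other changes at this place would transfer in the same way, nor does it explain why this one leaves the number in place.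

The compounds shown leave open whether a group of another kind at this place, such as an amine or a carboxylic acid, would move the number at all, and whether it would do so equally on both cores. They also leave open what a sulfoxide in place of the sulfide or the sulfone would give.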